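A few compounds are considered here, and "the series" means these few. Any claim that something is new, unique, unknown or untested is made for them only; others in the source may bear on it.

Of the compounds shown here, three with the shared core of compound 2 have been measured in a functional assay on HEK293 cells for agonist activity at Neuronal acetylcholine receptor; alpha4/beta2 (Homo sapiens), read by FLIPR; on this read-out lower numbers stand for an effect already at smaller amounts and higher numbers for an effect only at larger amounts of compound. Compound 1, `Clc1ccc(N2CC[C@H]3CN[C@H]3C2)cn1`, gives 13 nM. Its mirror image, compound 2, `Clc1ccc(N2CC[C@@H]3CN[C@@H]3C2)cn1`, gives 24 nM. Compound 3, `Cc1cc(N2CC[C@@H]3CN[C@@H]3C2)cnc1Cl`, which carries a methyl on the aromatic ring, gives 47 nM.

Compound 2 sits in the middle of these three numbers, and both of its neighbours lie within the scatter of it: the step of a 1.8-fold higher number from compound 1 to compound 2 (0.27 log units; within the scatter) rests on (the fact that compounds 1 and 2 differ only in the configuration as drawn), and the step of a 2.0-fold higher number from compound 2 to compound 3 (0.29 log units; within the scatter) is of a similar size. Neither of the measured steps alters the number beyond the scatter.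

The next compound, compound 4, `O=[N+]([O-])c1ccc(N2CC[C@@H]3CN[C@@H]3C2)cn1`, carries nitro in place of chloro on an aromatic carbon. Neither measured step touches this group, so the pair of steps gives only a sense of how little this core has moved so far in this assay. Nothing measured speaks to what the nitro group will do. On that footing, compound 2 is expected to hand down a step of a 1.7-fold higher number from compound 2 to compound 4 (0.22 log units; within the scatter) that is not more than a modest shift. The estimate for compound 4 in this assay is 40 nM, with a range from 10 nM to 160 nM.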

Compound 4, half-maximal effective concentration: 110 nM
Compound 4: middle estimate off by 2.8-fold (0.44 log units), on the low side; the measured number falls inside the stated range.
By their numbers in this assay, from the lowest: compounds 1, 2 and 3 (each within the scatter of the next, the first and the last beyond it); then compound 4.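

In this assay, among these compounds, nitro in place of chloro gives a 4.6-fold higher number from compound 2 to compound 4 (0.66 log units; beyond the scatter), and this is the first single change whose step lies beyond the scatter. Among the compounds shown here, the two earlier steps, the inversion of all stereocentres and the methyl in place of hydrogen on an aromatic carbon, both stayed within the scatter, so this position, on an aromatic carbon next to the ring nitrogen, is the first place on the shared core where one change is seen to shift the number, and the shift is towards an effect only at larger amounts of compound. Nothing at hand bears on why this replacement moves the number.

With a single replacement shown at this position, it stays open whether a nitrile, an amine, a methoxy group or a plain hydrogen there would shift the number as far as nitro does, or in the same direction. Going by these compounds, it also stays open whether nitro in place of chloro would give a step of similar size on the mirror-image core of compound 1 or alongside the methyl of compound 3.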